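Furyl-to-thienyl swap on a nucleoside scaffold, K562 growth

This account rests on a few compounds, and the source may have more. Where it says the series, first, only, none or still open, it means among the compounds named here.

Measured so far:
compound 1 `O=c1[nH]cnc2c1c(-c1ccoc1)cn2[C@@H]1O[C@H](CO)[C@@H](O)[C@H]1O` — 14500 nM
compound 2 `CN(C)c1ncnc2c1c(-c1ccoc1)cn2[C@@H]1O[C@H](CO)[C@@H](O)[C@H]1O` — 14900 nM

In a functional assay on K562 cells (Homo sapiens), read by MTT assay, with a stated time of 72 h (a higher number here means a weaker inhibitor, a lower number a stronger inhibitor), compound 1 gives 14500 nM. Its nearest neighbour on this number, compound 2, gives 14900 nM; the two values lie within the usual scatter of each other, so nothing separates them. Both compounds share the same furan-bearing core and differ only at the six-membered ring, and that difference leaves the read-out unchanged.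

Compound 3 `O=c1[nH]cnc2c1c(-c1cccs1)cn2[C@@H]1O[C@H](CO)[C@@H](O)[C@H]1O` is not yet measured. Relative to compound 1 the change is thiophen-2-yl in place of furan-3-yl on an aromatic carbon. Among the compounds with values here, no measured pair shows the effect of exchanging one five-membered heteroaryl for another at this position, so no step size can be read off. Given that compound 1 and compound 2 both sit at essentially the same weak level, a small step, or none beyond the scatter, is expected. The step from compound 1 to compound 3 is estimated as a 1.2-fold lower number from compound 1 to compound 3 (0.08 log units; within the scatter). For compound 3 the expected value is 12000 nM, with a range from 4000 nM to 40000 nM.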

Compound 3, half-maximal inhibitory concentration: > 20000 nM
Compound 3: a limit, no number; the forecaster's own chance of this, stated with the estimate: 10%; at least 1.6-fold (0.22 log units) between middle value and limit.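

In this assay compound 3 gives > 20000 nM, which is a limit of the assay and not a number. The exchange of furan-3-yl for thiophen-2-yl on this aromatic carbon gives an at least 1.3-fold higher number from compound 1 to compound 3 (0.13 log units; that floor lies within the scatter), so this first change at the position brings no sign of a lower number, though the true size of the step stays hidden. The step can be read only as a floor, and it says nothing about how far compound 3 lies from compound 1: the limit of > 20000 nM in this assay, at which 1 of the 3 values shown sits.

The swap alters both the hetero atom and the point of attachment, and the compounds shown do not separate the two; thiophen-3-yl on this carbon would do so. Also open, as far as these compounds go, is whether a non-aromatic group here, such as an aminomethyl group or a carboxylic acid, would move the number at all.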